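This account rests on a few compounds, and the source may have more. Where it says the series, first, only, none or still open, it means among the compounds named here.

Measured so far:
compound 1 `CSc1nc(-c2cccs2)c(C#N)c(=O)n1C` — 71 ug/mL
compound 2 `CCOC(=O)c1cnn(-c2nc(-c3ccc(OC)cc3)c(C#N)c(=O)n2C)c1N` — 59 ug/mL
compound 3 `COc1cccc(-c2nc(SC)n(C)c(=O)c2C#N)c1OC` — 54 ug/mL

All three numbers in a functional assay, with a stated time of 20 min (a lower number here means a stronger inhibitor, a higher number a weaker inhibitor), lie within the usual scatter of one another; compound 2 therefore cannot be ranked above or below compound 1 or compound 3, it simply sits with them. Compound 4 `CCOC(=O)c1cnn(-c2nc(-c3ccco3)c(C#N)c(=O)n2C)c1N` remains to be measured. It differs from compound 2 in one place: furan-2-yl in place of 4-methoxyphenyl on an aromatic carbon. Among the measured compounds shown here, no measured pair in this set shows the effect of such a change, and the three numbers so far barely spread despite quite different groups across the compounds. No movement beyond the scatter is expected, in either direction. The expected step is a 1.1-fold higher number from compound 2 to compound 4 (0.04 log units; within the scatter). Compound 4 is estimated to give 65 ug/mL in this assay, within 30 ug/mL to 140 ug/mL.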

Compound 4, half-maximal inhibitory concentration: 91 ug/mL
Compound 4: the middle estimate sits 1.4-fold (0.15 log units) below what was measured, and the stated range covers the measured number.
By their numbers in this assay, from the lowest: compounds 3, 2, 1 and 4 (each within the scatter of the next).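

In this assay, furan-2-yl in place of 4-methoxyphenyl gives a 1.5-fold higher number from compound 2 to compound 4 (0.19 log units; within the scatter), the first step read at this aromatic carbon, ortho to a cyano group. The position therefore takes a five-membered aromatic ring with 1 hetero atom in place of a six-membered aromatic ring of carbon only, with no movement beyond the scatter. No measurement bears on the reason for this result. From the compounds shown here alone, whether an amine or a carboxylic acid on this carbon would move the number beyond the scatter remains open.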